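The source may report more compounds than this note shows. Statements on the series, on what has been measured and on what is new or still open speak of the compounds shown alone.

Measured compounds in a toxicity assay on the whole organism (J774 cells) for cytotoxicity, with Mus musculus as the target, read by MTT assay, with a stated time of 24 h, tested at 10 uM; a higher number here means a weaker effect of the compound at the concentration tested, a lower number a stronger effect:
compound 1 `CCCCCCCCCO[C@@H]1[C@@H](N)[C@@H](OCC(O)CNCCCO)O[C@H](CN)[C@H]1OCCCCCCCCC` gives 89.9%
compound 2 `C=CCO[C@H]1O[C@H](CN)[C@@H](OCc2ccc3ccccc3c2)[C@H](OCc2ccc3ccccc3c2)[C@H]1N` gives 86.9%
compound 3 `C=CCO[C@H]1O[C@H](CN)[C@@H](OCCCc2ccc3ccccc3c2)[C@H](OCCCc2ccc3ccccc3c2)[C@H]1N` gives 105%

Compound 1 stands second highest of the three numbers in this assay. Its nearest neighbour is compound 2, whose number lies within the usual scatter of repeated measurements, so no order between the two can be read. Compound 3 is the furthest from compound 1, with a number beyond the scatter and higher, meaning the weaker effect at the concentration tested. Within the data shown here, all three measured numbers are high, so none of the measured compounds shows more than a modest effect under these conditions.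

Compound 4 `CCCCCCCCCO[C@@H]1[C@@H](N)[C@@H](OC[C@@H](O)CN)O[C@H](CN)[C@H]1OCCCCCCCCC` has not yet been measured in this assay. It differs from compound 1 in one place:

2-amino-1-hydroxyethyl in place of 1-hydroxy-2-((3-hydroxypropyl)amino)ethyl on a saturated chain carbon bound to an oxygen on a saturated carbon

The group that leaves and the group that enters both carry a nitrogen and a hydroxyl, and the group that enters is the smaller of the two. Among the measured compounds shown here, no pair of measured compounds shows a change of this kind, so neither size nor direction of the step can be taken from the series itself. Given the high numbers throughout, the step of a number 0.1 percentage points higher from compound 1 to compound 4 (within the scatter) is expected to stay within the scatter, with no clear direction. For compound 4 the estimate in this assay is 90%, with a range from 75% to 105%.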

Compound 4, a percentage reported as activity, at one concentration (the size of the read-out at that concentration, not a potency): 85.1%
For compound 4 the middle estimate is 4.9 percentage points above the measured one, and the stated range covers the measured number.
By their numbers in this assay, from the lowest: compounds 4, 2 and 1 (each within the scatter of the next); then compound 3.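

In this assay, among these compounds, the replacement of 1-hydroxy-2-((3-hydroxypropyl)amino)ethyl by 2-amino-1-hydroxyethyl gives a number 4.8 percentage points lower from compound 1 to compound 4 (within the scatter) and is the first readable step at this position on a saturated chain carbon bound to an oxygen on a saturated carbon. The 3-hydroxypropyl part on the nitrogen can therefore be removed from the core of compound 1 without the number leaving the scatter, so this one change gives no sign that this part matters in this assay at the tested concentration. No measurement at hand offers an explanation for this step or links it to a property of either group.

One step cannot separate the removal of the 3-hydroxypropyl part from the defined stereocentre carried by the entering group, and the series holds no second change at this position to compare it with. From the compounds shown here alone, whether a carboxylic acid in place of the amine, or a longer chain on the nitrogen, would move the number beyond the scatter remains open.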